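A few compounds are considered here, and "the series" means these few. Any claim that something is new, unique, unknown or untested is made for them only; others in the source may bear on it.

Measured compounds in a functional assay on A-431 cells (Homo sapiens) for cytotoxicity, read by MTT assay, with a stated time of 72 h, tested at 1 uM; on this read-out higher numbers stand for more inhibition of growth at the one concentration tested and lower numbers for less inhibition of growth:

compound 1 `N/C(=N\NC(=S)N1CCOCC1)c1ccccn1`: 29.2%
compound 2 `Cc1cccc(/C(N)=N/NC(=S)N2CCOCC2)n1`: 47.2%
compound 3 `Cc1ccnc(/C(N)=N/NC(=S)N2CCCCCC2)c1`: 36.3%

Compound 2 stands highest of the three numbers in this assay. Its nearest neighbour is compound 3, which gives 36.3%, a gap beyond the scatter; furthest is compound 1 with 29.2%, also beyond the scatter. Going by the values given here, the one step that can be isolated, a methyl in place of hydrogen on an aromatic carbon, is a number 18 percentage points higher from compound 1 to compound 2 (beyond the scatter).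

Compound 4 `Cc1cccc(/C(N)=N/NC(=S)N2CCCC2)n1` is not yet measured. It differs from compound 2 in one place: pyrrolidin-1-yl in place of morpholin-4-yl on a thiocarbonyl carbon. Among the compounds with values here, none of the measured steps changes this ring: compound 3 carries a seven-membered ring there, but it also differs from compound 2 in where the methyl sits, so its value shows no isolated effect of the ring alone. Within the data shown here, with no measured step bearing on this change, the expectation is a step of a number 5.2 percentage points lower from compound 2 to compound 4 (within the scatter), within the scatter and with no clear direction. Compound 4 is therefore estimated to give 42% in this assay, with a range from 22% to 62%.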

Compound 4, percent growth inhibition at one concentration: 21%
Beside the measured number, compound 4's estimate is 21 percentage points above it; measured number outside the range, below it.
By their numbers in this assay, from the lowest: compounds 4, 1 and 3 (each within the scatter of the next, the first and the last beyond it); then compound 2.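

In this assay, going by these compounds alone, the ring on the thiocarbonyl carbon proves to matter: with the rest of the molecule unchanged, pyrrolidin-1-yl in place of morpholin-4-yl gives a number 26.2 percentage points lower from compound 2 to compound 4 (beyond the scatter), the first isolated change at this position. The entering ring is five-membered and lacks the oxygen of the leaving ring, so ring size and the oxygen change together in this single step, and the step cannot separate them. No available evidence explains why the number falls.

The compounds shown leave open which of these two differences carries the step, a question that piperidin-1-yl, a six-membered ring without oxygen, could help answer. Also open, on these data alone, is how an open-chain dimethylamino group would compare on the same thiocarbonyl carbon.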